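Swapping Fluorophenyl for Benzimidazole: Lipophilicity Expectation

A few compounds are considered here, and "the series" means these few. Any claim that something is new, unique, unknown or untested is made for them only; others in the source may bear on it.

Measured compounds:
compound 1 `CNC(=O)c1cc(C(=O)NC2CC2)cn(Cc2ccc(F)cc2)c1=O`: 3.2
compound 2 `CNC(=O)c1cccn(Cc2ccccc2)c1=O`: 3

Of the compounds shown here, two have so far been measured in a physicochemical assay for lipophilicity, at pH 7.4; on this read-out higher numbers stand for higher lipophilicity and lower numbers for lower lipophilicity. Compound 1 gives 3.2, the higher of the two numbers, while compound 2 gives 3; the gap between them lies within the scatter, so the two cannot be told apart on this read-out. Within the data shown here, they differ in more than one place, so no single step can be drawn between them.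

Compound 3 `CNC(=O)c1cc(C(=O)NC2CC2)cn(Cc2ccc3nc[nH]c3c2)c1=O` has not been measured yet. It differs from compound 1 in a single place: 1H-benzimidazol-6-yl in place of 4-fluorophenyl on a saturated chain carbon bound to an aromatic nitrogen. The group that enters brings a hydrogen-bond donor and a hydrogen-bond acceptor, which the group that leaves lacks. For a change of this kind a fall in this assay clearly beyond the scatter is expected, so the step of a number 1.20 log units lower from compound 1 to compound 3 (beyond the scatter) is estimated to run downward. Compound 3 is accordingly expected to give 2, with a likely range from 1.3 to 2.7.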

Compound 3, distribution coefficient: 1.2
Compound 3: the middle estimate sits 0.80 log units above what was measured, outside the stated range (below it).
By their numbers in this assay, from the lowest: compound 3; then compounds 2 and 1 (each within the scatter of the next).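

In this assay, putting 1H-benzimidazol-6-yl in place of 4-fluorophenyl on a saturated chain carbon bound to an aromatic nitrogen gives a number 2.00 log units lower from compound 1 to compound 3 (beyond the scatter). This shows that the read-out is highly responsive to this one place on the shared core, even when one aromatic group replaces another and neither carries a net charge. The entering group differs in several ways at once, with a second ring, ring nitrogens, and a hydrogen-bond donor and acceptor, and nothing available explains the size of the step.

Which of these differences accounts for the step remains open. An indole or a methylated benzimidazole at the same place would help separate the contribution of each ring nitrogen and of the hydrogen on nitrogen.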